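Swapping Fluorine for Methyl on the Aryl Ring

The compounds below may be only part of what the source reports. "The series", "measured", "known", "first", "only" and "open" are said of these compounds alone.

Compound 1 `CC1=C(/C=C/C(=O)/C=C/c2ccccc2)C(C)(C)CCC1O` was tested in a functional assay on CWR22R cells (Homo sapiens) for cytotoxicity, read by MTT assay, with a stated time of 72 h (a lower number here means a stronger inhibitor, a higher number a weaker inhibitor), and compound 1 gives 8000 nM. Compound 2 `CC1=C(/C=C/C(=O)/C=C/c2ccc(F)cc2)C(C)(C)CCC1O` gives 7500 nM in the same assay, so that a 1.1-fold lower number from compound 1 to compound 2 (0.03 log units; within the scatter) is a step too small to read as a change; compound 2 stands alongside compound 1 on these numbers. Compound 3 `CC1=C(/C=C/C(=O)/C=C/c2cccc(C)c2)C(C)(C)CCC1O` carries 3-methylphenyl in place of 4-fluorophenyl on a double-bonded chain carbon bound to a double-bonded chain carbon. Going by the values given here, no measured step covers this exact change, and the single step known, fluoro for hydrogen, stayed within the scatter. The expectation is therefore a 1.1-fold lower number from compound 2 to compound 3 (0.03 log units; within the scatter), and compound 3 is estimated at 7000 nM, with a range from 3000 nM to 18000 nM.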

Compound 3, half-maximal inhibitory concentration: 4400 nM
For compound 3 the middle estimate is 1.6-fold (0.20 log units) above the measured one; low and high end bracket the measured number.
By their numbers in this assay, from the lowest: compounds 3, 2 and 1 (each within the scatter of the next).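

In this assay, a methyl group on the aromatic ring gives a 1.8-fold lower number from compound 1 to compound 3 (0.26 log units; within the scatter), and the swap of 4-fluorophenyl for 3-methylphenyl gives a 1.7-fold lower number from compound 2 to compound 3 (0.23 log units; within the scatter). A carbon-only group on the ring therefore stays within the scatter, just as the fluoro step did, so neither change can be read as a real shift. No outside measurement is available to explain these numbers.

On these data alone, whether an amine or a carboxylic acid on the aromatic ring would give a step beyond the scatter remains open.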